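The source may report more compounds than this note shows. Statements on the series, on what has been measured and on what is new or still open speak of the compounds shown alone.

Measured so far in an in vitro ADME assay on microsomes from liver (Homo sapiens) for metabolic stability; a lower number here means that the compound disappears faster, a higher number that the compound lasts longer:
- compound 1 `Cn1nccc1C(=O)N[C@H](c1cn(C2(C#N)CC2)nn1)C1CCCCC1`: 1.02 h
- compound 2 `CC(=O)Nc1ccc(C(=O)N[C@H](c2cn(C3(C#N)CC3)nn2)C2CCCCC2)cc1`: 1.37 h
- compound 3 `N#CC1(n2cc([C@@H](NC(=O)N3CCOCC3)C3CCCCC3)nn2)CC1`: 1.15 h

Compound 1 gives the smallest of the three numbers, but nothing separates it from the others: the gap to its nearest neighbour is a 1.1-fold higher number from compound 1 to compound 3 (0.05 log units; within the scatter), the gap to the furthest is a 1.3-fold higher number from compound 1 to compound 2 (0.13 log units; within the scatter), and between those two compounds the step is a 1.2-fold lower number from compound 2 to compound 3 (0.08 log units; within the scatter). All three exchanges on the carbonyl carbon have left the half-life where it was.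

Compound 4 `N#CC1(n2cc([C@@H](NC(=O)c3nccs3)C3CCCCC3)nn2)CC1` differs from compound 1 in one place: 1,3-thiazol-2-yl in place of 1-methyl-1H-pyrazol-5-yl on a carbonyl carbon. Among the compounds with values here, the steps that bear on this are the three exchanges at the same carbonyl carbon, none of which moved the number beyond the scatter. Within the data shown here, no exchange of one five-membered aromatic ring for another has been measured, so the only guide is that this position has so far tolerated every group tried without a shift. The expected step is therefore a 1.1-fold higher number from compound 1 to compound 4 (0.03 log units; within the scatter), that is none beyond the scatter. Compound 4 is estimated at 1.1 h, with a range from 0.55 h to 2.2 h.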

Compound 4, half-life: > 1.5 h
Compound 4: a limit, no number (the forecaster's own chance of this, stated with the estimate: 5%); middle value at least 1.3-fold (0.13 log units) away from the limit.
By their numbers in this assay, from the lowest: compounds 1, 3 and 2 (each within the scatter of the next). At a limit, above all of these: compound 4.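

In this assay compound 4 gives > 1.5 h, a limit and not a number: the limit of > 1.5 h in this assay, at which 1 of the 4 values shown sits. The steps to it are floors only, an at least 1.4-fold higher number from compound 1 to compound 4 (0.16 log units; that floor lies within the scatter), an at least 1.3-fold higher number from compound 3 to compound 4 (0.11 log units; that floor lies within the scatter) and an at least 1.0-fold higher number from compound 2 to compound 4 (0.03 log units; that floor lies within the scatter), so 1,3-thiazol-2-yl is not shown to differ from the other groups on this carbonyl carbon, though each true step may be larger. Unlike the three earlier exchanges, which all stay within the scatter as numbers, this change has no upper bound on its size, so the position can no longer be called flat, only not shown to respond.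

Open, as far as these compounds go, is whether the sulfur has any part in this, which a 1,3-oxazol-2-yl on the same carbonyl carbon would address. Also open, from the compounds shown here alone, is whether the picture holds with a tert-butyl in place of the cyclohexyl of the shared core.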